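Pyrazolyl amine in place of methylpiperazinyl amine

The source may report more compounds than this note shows. Statements on the series, on what has been measured and on what is new or still open speak of the compounds shown alone.

Measured so far:
compound 1 `Cc1ccc(CNC(=O)c2cccc(C(C)Oc3ccnc(NN4CCN(C)CC4)c3)c2)cc1` gives 8100 nM in a functional assay on NCI-H3122 cells (Homo sapiens) for antiproliferative activity, read by MTT assay, with a stated time of 48 h; on this read-out higher numbers stand for weaker inhibition and lower numbers for stronger inhibition;
compound 2 `CC(Oc1ccnc(NN2CCN(C)CC2)c1)c1cccc(C(=O)NCc2ccc(Cl)c(C(F)(F)F)c2)c1` gives 21700 nM in this assay.

Compound 2 has the higher of the two numbers; compound 1 sits a 2.7-fold higher number from compound 1 to compound 2 (0.43 log units; beyond the scatter) away. Compound 3 `CC(Oc1ccnc(Nc2cnn(CC(C)(C)O)c2)c1)c1cccc(C(=O)NCc2ccc(Cl)c(C(F)(F)F)c2)c1` differs from compound 2 at the other end of the shared core: 1-(2-hydroxy-2-methylpropyl)-1H-pyrazol-4-yl in place of 4-methylpiperazin-1-yl on a nitrogen on an aromatic ring. Going by the values given here, no measured step touches this part of the molecule; the single step from compound 1 to compound 2 concerns only the group on the saturated chain carbon bound to the amide-type nitrogen, so it says nothing about the direction of the present change. Among the compounds with values here, the expectation for compound 3 therefore rests on no comparable step and is given with a wide range. Compound 3 is estimated at 4000 nM in this assay, between 300 nM and 30000 nM, which would be a step of a 5.4-fold lower number from compound 2 to compound 3 (0.73 log units; beyond the scatter).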

Compound 3, half-maximal inhibitory concentration: 38400 nM
Compound 3: the middle estimate sits 9.6-fold (0.98 log units) below what was measured, and the stated range ends below it.
By their numbers in this assay, from the lowest: compound 1; then compounds 2 and 3 (each within the scatter of the next).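

With the 4-chloro-3-(trifluoromethyl)phenyl group held constant, the exchange of 4-methylpiperazin-1-yl for 1-(2-hydroxy-2-methylpropyl)-1H-pyrazol-4-yl on the nitrogen on an aromatic ring gives a 1.8-fold higher number from compound 2 to compound 3 (0.25 log units; within the scatter) in this assay. Going by these compounds alone, this is the first reading at this end of the molecule, and it shows that a saturated ring and an aromatic ring carrying a hydroxyl-bearing chain cannot be told apart here, so this single change gives no gain in the read-out. Nothing available explains this result.

The compounds shown leave open whether a smaller group at this place, such as 1-methyl-1H-pyrazol-4-yl, or a morpholin-4-yl ring would read differently. They also leave open whether the same exchange would read alike with the 4-methylphenyl group of compound 1 at the other end.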